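From Fluoro to Chloro: Expecting Compound 4

The source may hold more compounds than are shown below. What is called first, only, known or untested is meant among the compounds shown, and "the series" means these compounds.

Three compounds that share one core have been compared in a functional assay on HT-1080 cells (Homo sapiens), read by transwell migration, with a stated time of 24 h, tested at 1 uM; a lower number here means a stronger effect, a higher number a weaker effect of the compound at the concentration tested. Compound 1 `CC(=O)OCc1ccc2oc(=O)c(C(=O)Oc3cccc(Cl)c3)cc2c1` gives 49.1%. Compound 2 `NCc1ccc2oc(=O)c(C(=O)Oc3ccccc3)cc2c1` gives 85.5%, and compound 3 `NCc1ccc2oc(=O)c(C(=O)Oc3cccc(F)c3)cc2c1` gives 45.3%. Of these three numbers, compound 3 has the lowest, but it lies within the scatter of compound 1 and stands clearly apart only from compound 2. Going by the values given here, the single step measured between compounds differing in one place is a number 40.2 percentage points lower from compound 2 to compound 3 (beyond the scatter), a large change that is beyond the scatter.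

The unmeasured compound 4 `NCc1ccc2oc(=O)c(C(=O)Oc3cccc(Cl)c3)cc2c1` differs from compound 3 by chloro in place of fluoro on an aromatic carbon. Among the compounds with values here, no measured step swaps one halogen for another. Compound 1 does carry the chloro group, yet it also differs from compound 3 elsewhere on the core, so its value cannot be credited to the chloro group alone; still, compound 1 and compound 3 read alike within the scatter, which gives no sign that chloro in this place moves the number far from where fluoro puts it. The step in this assay is therefore expected to be small, a number 0.7 percentage points higher from compound 3 to compound 4 (within the scatter), within the scatter in either direction. Compound 4 is expected to give about 46%, with a range from 30% to 63%.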

Compound 4, a percentage reported as activity, at one concentration (the size of the read-out at that concentration, not a potency): 86.6%
The estimate for compound 4 lay 40.6 percentage points below the measured number; measured number above the stated range.
By their numbers in this assay, from the lowest: compounds 3 and 1 (each within the scatter of the next); then compounds 2 and 4 (each within the scatter of the next).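

In this assay, a swap of one halogen for another at this place on the ring is not a minor edit: a number 41.3 percentage points higher from compound 3 to compound 4 (beyond the scatter), so the 3-fluorophenyl and 3-chlorophenyl esters cannot be treated as interchangeable when the chain carries the amino group. Adding chloro in place of hydrogen leaves the number within the scatter, a number 1.1 percentage points higher from compound 2 to compound 4 (within the scatter), so among these three amino compounds only fluoro stands apart, and the lower number does not extend to halogens in general. With chloro held fixed, the group on the saturated chain carbon matters as well, since amino in place of acetoxy gives a number 37.5 percentage points higher from compound 1 to compound 4 (beyond the scatter), and the close reading of compound 1 and compound 3 therefore says little about chloro on its own.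

Nothing available explains why fluoro and chloro part so sharply here. Still open, from the compounds shown here alone, is whether bromo, methyl or methoxy at this place would read like fluoro or like chloro, and whether fluoro paired with acetoxy on the chain would keep a low number.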